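Working notes on the series: compound 3 to compound 4

The source may hold more compounds than are shown below. What is called first, only, known or untested is meant among the compounds shown, and "the series" means these compounds.

Measured in an assay on thoracic aorta for binding affinity to Endothelin-1 receptor (Rattus norvegicus); on this read-out lower numbers stand for stronger inhibition and higher numbers for weaker inhibition:
compound 1 `Cc1noc(NS(=O)(=O)c2ccc(N)c3ccccc23)c1C` gives 3500 nM
compound 2 `Cc1noc(NS(=O)(=O)c2cccc3cc(N(C)C)ccc23)c1C` gives 840 nM
compound 3 `Cc1noc(NS(=O)(=O)c2cccc3ccc(N)cc23)c1C` gives 1450 nM

Compound 3 holds the second highest of the three numbers. Its nearest neighbour is compound 2, whose value lies within the scatter of repeated measurements, so the two cannot be told apart on these data. Compound 1 gives a higher number than compound 3, and that gap lies beyond the scatter. Going by the values given here, no single-change step between measured compounds is at hand, so the move to compound 4 `CC(=O)Nc1ccc2cccc(S(=O)(=O)Nc3onc(C)c3C)c2c1` has no direct precedent. Compound 4 differs from compound 3 by acetyl in place of hydrogen on a nitrogen on an aromatic ring, in other words acetyl in place of hydrogen on a nitrogen on an aromatic ring, amino to acetamido. With nothing in the series to set the scale, the expected step from compound 3 to compound 4 in this assay is a 1.2-fold higher number from compound 3 to compound 4 (0.09 log units; within the scatter), taken to be none beyond the scatter. Compound 4 is accordingly estimated at 1800 nM in this assay, with a range from 600 nM to 5500 nM.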

Compound 4, half-maximal inhibitory concentration: 870 nM
Beside the measured number, compound 4's estimate is 2.1-fold (0.32 log units) above it; the range from low to high includes it.
By their numbers in this assay, from the lowest: compounds 2, 4 and 3 (each within the scatter of the next); then compound 1.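

In this assay, going by these compounds alone, the first single-change step, acetyl in place of hydrogen on a nitrogen on an aromatic ring, reads as a 1.7-fold lower number from compound 3 to compound 4 (0.22 log units; within the scatter) and so leaves the two compounds indistinguishable. At this position, amino to acetamido is tolerated: the nitrogen takes the acetyl with its 3 heavy atoms, and the free amino group is not needed to hold a number in this range. No measurement at hand bears on why the step is this small.

On these data alone, whether a larger acyl group such as benzoyl, or a methanesulfonyl group, on this nitrogen would stay within the scatter of compound 3 remains open. Also open, as far as these compounds go, is whether a carboxylic acid or a longer chain in place of the acetyl would give a step beyond the scatter in this assay, in either direction.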